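Quinolinone Imines: A Methyl-to-Hydrogen Step Repeated

The compounds below may be only part of what the source reports. "The series", "measured", "known", "first", "only" and "open" are said of these compounds alone.

Measured compounds:
Compound 1, `Cc1ccc2[nH]c(=O)c(/C=N/c3ccc(O)cc3)cc2c1`, 235000 nM
Compound 2, `O=c1[nH]c2ccccc2cc1/C=N/c1ccc(O)cc1`, 306000 nM
Compound 3, `Cc1ccc2[nH]c(=O)c(/C=N/Nc3ccc([N+](=O)[O-])cc3[N+](=O)[O-])cc2c1`, recorded as "not active" (no number reported) with no number reported

In a functional assay, read by spectrophotometry, with a stated time of 5 min (on this read-out lower numbers stand for stronger inhibition and higher numbers for weaker inhibition), compound 1 gives 235000 nM and compound 2 gives 306000 nM. The two differ by hydrogen in place of methyl on an aromatic carbon, and that change gave a 1.3-fold higher number from compound 1 to compound 2 (0.11 log units; within the scatter). Compound 3 is recorded in this assay as "not active" (no number reported), so no single number stands for it; the difference between the core of compound 1 and the core of compound 3 is not broken down here.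

Compound 4, `O=c1[nH]c2ccccc2cc1/C=N/Nc1ccc([N+](=O)[O-])cc1[N+](=O)[O-]`, is not yet measured. It differs from compound 3 by hydrogen in place of methyl on an aromatic carbon, the same change that separates compound 1 from compound 2, and this change occurs twice among the compounds shown. The earlier step stayed within the scatter, and compound 3 gave no number at all, so the same kind of outcome is expected here. Compound 4 is expected to give about 500000 nM in this assay, with a range estimated from 200000 nM to 2000000 nM, and most likely only a limit rather than a number.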

Compound 4, half-maximal inhibitory concentration: "not active" (no number reported)
For compound 4 the study gives words and no number; no gap can be computed for the estimate.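

Compound 3 and compound 4 are both recorded in this assay as not active, without a number, so no new step can be read between them. No available evidence bears on this result.
The compounds shown leave open whether hydrogen in place of methyl has any measurable size of effect on the core of compound 3.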